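Splenocyte inhibitors: a guaiacol-type amide after an ortho-methyl benzamide

The source may report more compounds than this note shows. Statements on the series, on what has been measured and on what is new or still open speak of the compounds shown alone.

The measured compounds are compound 1 `CC(/C=N/Nc1ccc([N+](=O)[O-])cc1)=N\NC(=O)c1ccccc1Cl`, compound 2 `CC(/C=N/Nc1ccc([N+](=O)[O-])cc1)=N\NC(=O)c1ccc(O)cc1` and compound 3 `CC(/C=N/Nc1ccc([N+](=O)[O-])cc1)=N\NC(=O)c1ccccc1C`. In a functional assay on cells (Splenocyte, Mus musculus, strain BALB/c) for inhibition, read by scintillation counting and thymidine incorporation, with a stated time of 72 h (a lower number here means a stronger inhibitor, a higher number a weaker inhibitor), compound 1 gives only a limit, > 12000 nM. Compound 2 gives 1510 nM and compound 3 gives 6000 nM. Compound 3 stands highest of the two numbers; the step of a 4.0-fold higher number from compound 2 to compound 3 (0.60 log units; beyond the scatter) is modest and beyond the scatter.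

Compound 4 `COc1cc(C(=O)N/N=C(C)/C=N/Nc2ccc([N+](=O)[O-])cc2)ccc1O` carries 4-hydroxy-3-methoxyphenyl in place of 2-methylphenyl on a carbonyl carbon. Among the measured compounds shown here, the step that bears on it most is a 4.0-fold higher number from compound 2 to compound 3 (0.60 log units; beyond the scatter), which runs in the opposite direction, so reverting to a 4-hydroxy bearing ring is expected to give a lower number; the added methoxy has no measured counterpart. For this assay compound 4 is expected at 1800 nM, between 600 nM and 5500 nM, a step of a 3.3-fold lower number from compound 3 to compound 4 (0.52 log units; beyond the scatter).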

Compound 4, half-maximal inhibitory concentration: 5100 nM
Compound 4: middle estimate off by 2.8-fold (0.45 log units), on the low side, within the range that was stated.
By their numbers in this assay, from the lowest: compound 2; then compounds 4 and 3 (each within the scatter of the next). At a limit, above all of these: compound 1.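

Adding a methoxy to the 4-hydroxy ring gives the first measured change at that ring without swapping the ring itself, and it costs potency: a 3.4-fold higher number from compound 2 to compound 4 (0.53 log units; beyond the scatter). On the carbonyl carbon, 4-hydroxy-3-methoxyphenyl and 2-methylphenyl cannot be told apart, with a 1.2-fold lower number from compound 3 to compound 4 (0.07 log units; within the scatter). The step of an at least 2.3-fold lower number from compound 1 to compound 4 (0.37 log units; beyond the scatter) is only a floor, since it starts from a limit: the limit of > 12000 nM in this assay, at which 1 of the 4 values shown sits.

On these data alone, whether an ethoxy group or an amine in place of the methoxy would stay closer to compound 2 remains open. So does whether the methoxy step recurs on other rings.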